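The source may hold more compounds than are shown below. What is called first, only, known or untested is meant among the compounds shown, and "the series" means these compounds.

In a functional assay, with stated times of 30 s and 6 min, in the presence of a further agent that is not named here (a lower number here means a stronger inhibitor, a higher number a weaker inhibitor), compound 1 (`CCCCOc1cc(OC)ccc1C(C)=O`) gives 15600000 nM and compound 2 (`CCCCCCCCOc1cc(OC)ccc1C(C)=O`) gives 21200000 nM as half-maximal inhibitory concentrations. Going by the values given here, compound 2 thus stands within the scatter of the only other measured compound, and the two cannot be told apart. Compound 3 (`CCCCCCCCCCOc1cc(OC)ccc1C(C)=O`) extends the same chain of compound 2 by one further change (ethyl in place of hydrogen on a saturated chain carbon, eight bonds along the chain from an oxygen on an aromatic ring) and has not yet been measured. Among the compounds with values here, one measured step bears on this change, and a single step sets no trend. Within the data shown here, no step beyond the scatter is expected in this assay because a 1.4-fold higher number from compound 1 to compound 2 (0.13 log units; within the scatter) is the only guide and it came from a chain extension with butyl, while this one adds ethyl. The step expected is small (a 1.1-fold higher number from compound 2 to compound 3 (0.05 log units; within the scatter)) and is not expected to leave the scatter. Compound 3 is estimated at 24000000 nM with an expected range from 12000000 nM to 45000000 nM in this measurement.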

Compound 3, half-maximal inhibitory concentration: 26600000 nM
Beside the measured number, compound 3's estimate is 1.1-fold (0.04 log units) below it, and the stated range covers the measured number.
By their numbers in this assay, from the lowest: compounds 1, 2 and 3 (each within the scatter of the next).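

In this assay, going by these compounds alone, ethyl in place of hydrogen on a saturated chain carbon, eight bonds along the chain from an oxygen on an aromatic ring, gives a 1.3-fold higher number from compound 2 to compound 3 (0.10 log units; within the scatter) and so no step that can be told from the scatter at this position. Taken across the whole series, the direct comparison gives a 1.7-fold higher number from compound 1 to compound 3 (0.23 log units; within the scatter) and stays within the scatter as well, so compounds 1, 2 and 3 cannot be told apart in this measurement. No measurement given here offers an explanation for these numbers.

As far as these compounds go, whether a still longer chain would leave the scatter remains open. So does the effect of a carboxylic acid or an amine at the end of the chain on the shared core.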